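The compounds below may be only part of what the source reports. "The series", "measured", "known", "first", "only" and "open" are said of these compounds alone.

The series shares one core, carried by compound 1 `CC[C@H](C)[C@H](NC(=O)c1cccc(Cn2ccnc2)c1)C(=O)Nc1nccs1` and varied at the amide end. In an assay on HEK293 cells for displacement of a labelled ligand from Type-2 angiotensin II receptor (Homo sapiens), tested at 10 uM (on this read-out higher numbers stand for a stronger effect at the one concentration tested and lower numbers for a weaker effect), compound 1 gives 17%, a weak displacement at the single concentration tested. Compound 2 `CCCCS(=O)(=O)NNC(=O)[C@@H](NC(=O)c1cccc(Cn2ccnc2)c1)[C@@H](C)CC` carries a butylsulfonyl hydrazide in that position; in this assay compound 2 gives "not determined" (no result reported), so it stands without a number of its own, and nothing about its effect can be read from the data. Compound 3 `CC[C@H](C)[C@H](NC(=O)c1cccc(Cn2ccnc2)c1)C(=O)NS(=O)(=O)c1ccccc1` arises from compound 2 by the change (phenylsulfonyl in place of (butylsulfonyl)amino on an amide-type nitrogen). Since compound 2 has no value, the step from compound 2 to compound 3 cannot be sized from any measured pair; with compound 1 as the only reference point, a result of the same weak order is anticipated, with no direction claimed beyond the scatter. Compound 3 is therefore expected to give about 20% in this assay, in a range from 0% to 50%.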

Compound 3, a percentage reported as inhibition, at one concentration (the size of the read-out at that concentration, not a potency): 24%
Estimate against measurement, compound 3: 4 percentage points below, and the stated range covers the measured number.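

In this assay, phenylsulfonyl in place of 1,3-thiazol-2-yl on an amide-type nitrogen gives a number 7 percentage points higher from compound 1 to compound 3 (within the scatter), so the two groups cannot be told apart on this read-out. This gives the series its first readable comparison at this position, and it shows that a sulfonyl-bearing group and an aromatic five-membered ring can occupy the position with no change beyond the scatter. Compound 2 has no number, so its step to compound 3 cannot be read, and nothing at hand explains why compound 1 and compound 3 read alike.

On these data alone, whether a pyridine ring or a longer alkyl chain on that nitrogen would lift the displacement clear of this weak level stays open. So does the effect of the butylsulfonyl hydrazide of compound 2 itself.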